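Aryl sulfonate amides: ethyl to pentylamino at the carbonyl

This account rests on a few compounds, and the source may have more. Where it says the series, first, only, none or still open, it means among the compounds named here.

Measured so far:
compound 1 `CC(C)c1ccccc1OS(=O)(=O)c1cccc(NC(=O)CCl)c1`, a functional assay on M21 cells (Homo sapiens) for antiproliferative activity, read by sulforhodamine B assay, with a stated time of 48 h; on this read-out lower numbers stand for stronger inhibition and higher numbers for weaker inhibition: 3900 nM
compound 2 `CCC(=O)Nc1ccc(S(=O)(=O)Oc2ccccc2C(C)C)cc1`, this assay: 11000 nM

Compound 2 stands highest of the two numbers; compound 1 is the nearer, with a lower number, a gap beyond the usual scatter. Compound 3 `CCCCCNC(=O)Nc1ccc(S(=O)(=O)Oc2ccccc2C(C)C)cc1` follows from compound 2 by one change: pentylamino in place of ethyl on a carbonyl carbon. For the measured compounds named here, no step between measured compounds bears on this change, so only a modest move is expected, probably toward a lower number, though nothing beyond the scatter can be ruled out. The expected step of a 1.8-fold lower number from compound 2 to compound 3 (0.26 log units; within the scatter) is therefore small. Compound 3 is estimated at 6000 nM, with a range of 1500 nM to 25000 nM.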

Compound 3, half-maximal inhibitory concentration: 4600 nM
Compound 3: middle estimate off by 1.3-fold (0.12 log units), on the high side, and the stated range covers the measured number.
By their numbers in this assay, from the lowest: compounds 1 and 3 (each within the scatter of the next); then compound 2.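

In this assay, for the compounds shown here, pentylamino in place of ethyl on a carbonyl carbon gives a 2.4-fold lower number from compound 2 to compound 3 (0.38 log units; beyond the scatter) and is the first step read at this position. The position therefore accepts the change from propanoylamino to (pentylcarbamoyl)amino, with a modest fall in the number rather than a loss of activity. No measurement at hand accounts for this step. Still open, as far as these compounds go, is whether the pentyl chain or the added nitrogen carries the step. Ethylamino and a plain hexyl chain on the same carbonyl carbon would bear on that question.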